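Lengthening the chlorophenoxy linker by one carbon

The source may report more compounds than this note shows. Statements on the series, on what has been measured and on what is new or still open speak of the compounds shown alone.

Measured so far:
compound 1 `O=C1N(CCCCCCCOc2ccc(Br)cc2)CCN1c1ccncc1` – > 25000 nM
compound 2 `O=C1N(CCCCCCOc2ccc(Cl)cc2)CCN1c1ccncc1` – > 25000 nM

In a functional assay on cells (Homo sapiens) for cytotoxicity (a lower number here means that less compound is tolerated, a higher number that more compound is tolerated), compound 2 reaches only a limit, not a number. Compound 1 likewise stops at a limit, so the step that the two limits leave unreadable from compound 1 to compound 2 has no readable size. The unmeasured compound 3 `O=C1N(CCCCCCCOc2ccc(Cl)cc2)CCN1c1ccncc1` differs from compound 2 by (4-chlorophenoxy)methyl in place of 4-chlorophenoxy on a saturated chain carbon, six bonds along the chain from an amide-type nitrogen in a ring. Among the compounds with values here, the only measured step bears on this change but cannot be sized, and both values shown sit at the same limit (the limit of > 25000 nM in this assay, at which 2 of the 2 values shown sit). No change beyond the scatter is therefore expected in this assay, and another limit is the likely outcome. Compound 3 is estimated at 40000 nM, with a range from 20000 nM to 100000 nM. The expected step is a step that the limit leaves unreadable from compound 2 to compound 3.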

Compound 3, half-maximal cytotoxic concentration: > 25000 nM
Compound 3 gave a limit, no number (the forecaster's own chance of this, stated with the estimate: 85%); the middle value is on the limit's open side.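

Compound 1, compound 2 and compound 3 each give a limit, not a number, in this assay and so no step among them can be read: the limit of > 25000 nM in this assay, at which 3 of the 3 values shown sit.

From the compounds shown here alone, how far each compound lies past that limit, and whether chain length or the halogen matters at all, stays open.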